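This account rests on a few compounds, and the source may have more. Where it says the series, first, only, none or still open, it means among the compounds named here.

Measured so far in a functional assay on HCT-15 cells (Homo sapiens) for cytotoxicity, read by sulforhodamine B assay, tested at 10 uM; a higher number here means more inhibition at the concentration tested (going by the name of the read-out), a lower number less inhibition:
compound 1 `CC(=O)OC[C@H]1O[C@@H](n2cc(-c3cn(Cc4ccc(C(C)C)cc4)nn3)c(=O)[nH]c2=O)C[C@@H]1OC(C)=O`: 96.5%
compound 2 `CC(=O)OC[C@H]1O[C@@H](n2cc(-c3cn(Cc4ccccc4)nn3)c(=O)[nH]c2=O)C[C@@H]1OC(C)=O`: 92.3%

Compound 2 holds the lowest of the two numbers in this assay, with compound 1 nearest; the gap a number 4.2 percentage points lower from compound 1 to compound 2 (within the scatter) lies within the scatter, so neither stands apart. Compound 3 `CC(=O)OC[C@H]1O[C@@H](n2cc(-c3cn(Cc4ccc(C(C)(C)C)cc4)nn3)c(=O)[nH]c2=O)C[C@@H]1OC(C)=O` differs from compound 2 by tert-butyl in place of hydrogen on an aromatic carbon. Within the data shown here, the only measured step that bears on this change is the one from compound 1 to compound 2, where a branched alkyl gave way to hydrogen without moving the number beyond the scatter. Putting a branched alkyl back is therefore expected to give no step beyond the scatter. Compound 3 is estimated at 95%, within 87% to 99%. The expected step is a number 2.7 percentage points higher from compound 2 to compound 3 (within the scatter).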

Compound 3, a percentage reported as inhibition, at one concentration (the size of the read-out at that concentration, not a potency): 94.2%
Compound 3: middle estimate off by 0.8 percentage points, on the high side, and the stated range covers the measured number.
By their numbers in this assay, from the lowest: compounds 2, 3 and 1 (each within the scatter of the next).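

In this assay, tert-butyl on the aromatic carbon para to a large group gives a number 1.9 percentage points higher from compound 2 to compound 3 (within the scatter), so a second branched alkyl at this position also stays within the scatter of hydrogen. The extra methyl that turns isopropyl into tert-butyl, read in reverse order of size, gives a number 2.3 percentage points lower from compound 1 to compound 3 (within the scatter), so this added branching shows no readable difference either. Nothing at hand gives a reason for this flat result.

As far as these compounds go, whether an amine or a carboxylic acid at this position would hold the number stays open. So does whether these three compounds would separate at a lower concentration.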